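Ester to Amide at the Edge of a Shared Core

This account rests on a few compounds, and the source may have more. Where it says the series, first, only, none or still open, it means among the compounds named here.

Of the compounds shown here, three have been measured in an assay on isolated protein for inhibition of Gonadotropin-releasing hormone receptor (Rattus norvegicus); on this read-out lower numbers stand for stronger inhibition and higher numbers for weaker inhibition. Compound 1, `COc1ccc([N+](=O)[O-])cc1CSc1nc2cc(NC(=O)NC(C)(C)C)ccc2n1Cc1cccnc1`, gives 150 nM. Compound 2, `COc1ccc([N+](=O)[O-])cc1CSc1nc2cc(NC(=O)C3CCC3)ccc2n1C(C)C`, gives 630 nM. Compound 3, `CCCn1c(SCc2cc([N+](=O)[O-])ccc2OC)nc2cc(NC(=O)NC(C)(C)C)cc(C(=O)OC)c21`, gives 280 nM. Among these three numbers compound 3 holds the second highest. Its gap to compound 1 lies within the usual scatter of repeated measurements, so the two cannot be told apart on this read-out. Its gap to compound 2 lies beyond that scatter, with compound 2 showing the higher number of the pair.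

Compound 4, `CCCn1c(SCc2cc([N+](=O)[O-])ccc2OC)nc2cc(NC(=O)NC(C)(C)C)cc(C(=O)NCc3ccccc3)c21`, is not yet measured. It differs from compound 3 in one place: benzylamino in place of methoxy on a carbonyl carbon. Within the data shown here, no two of the measured compounds differ from each other in a single place, so there is no measured step to lean on for the size of this change. The expectation therefore rests on compound 3 alone, and the change is expected to move the number little, with a step from a 1.3-fold lower number from compound 3 to compound 4 (0.10 log units; within the scatter) that stays close to the scatter. Compound 4 is estimated at 220 nM, with a range from 70 nM to 700 nM.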

Compound 4, half-maximal inhibitory concentration: 130 nM
Estimate against measurement, compound 4: 1.7-fold (0.23 log units) above; the range from low to high includes it.
By their numbers in this assay, from the lowest: compounds 4, 1 and 3 (each within the scatter of the next, the first and the last beyond it); then compound 2.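

Replacing methoxy with benzylamino on this carbonyl carbon gives, in this assay, a 2.2-fold lower number from compound 3 to compound 4 (0.33 log units; beyond the scatter), a modest step but one that lies beyond the usual scatter. The earlier compounds shown here carried nothing that spoke to this place, and this step shows that it tolerates much more than the small methoxy: methoxycarbonyl becomes benzylcarbamoyl, a six-membered aromatic ring and a hydrogen-bond donor come in, and the number falls instead of rising. No measurement at hand says which part of this change accounts for the lower number.

The compounds shown leave open whether the aromatic ring or the amide hydrogen matters more, a question that a plain methylamino, a longer chain such as phenethylamino, or a free carboxylic acid on the same carbonyl carbon could help to answer. Also open, from the compounds shown here alone, is whether the same step would appear with other groups elsewhere on the shared core, since this single pair shows it only with the groups that compound 3 and compound 4 have in common.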